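A few compounds are considered here, and "the series" means these few. Any claim that something is new, unique, unknown or untested is made for them only; others in the source may bear on it.

Measured in a functional assay on K562 cells (Homo sapiens) for cytotoxicity, read by trypan blue exclusion, with a stated time of 96 h; a lower number here means a stronger inhibitor, a higher number a weaker inhibitor:
- compound 1 `COC(=O)C(C)(C)Nc1cc(CS(=O)(=O)/C=C/c2c(OC)cc(OC)cc2OC)ccc1OC` gives 800 nM
- compound 2 `COC(=O)C(Nc1cc(CS(=O)(=O)/C=C/c2c(OC)cc(OC)cc2OC)ccc1OC)c1ccc(Cl)cc1` gives 200 nM
- compound 3 `COc1cc(OC)c(/C=C/S(=O)(=O)Cc2ccc(OC)c(NCCC(=O)O)c2)c(OC)c1` gives 5000 nM

Compound 3 has the highest number of the three and is the weakest inhibitor in this small set. Among the measured compounds shown here, it is also the only one with a carboxyethyl group on the nitrogen, where compound 1 and compound 2 carry groups with a methoxycarbonyl.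

The next compound is compound 4 `COc1cc(OC)c(/C=C/S(=O)(=O)Cc2ccc(OC)c(N[C@@H](C)C(=O)O)c2)c(OC)c1`, and the change is 1-carboxyethyl in place of 2-carboxyethyl on a nitrogen on an aromatic ring.

For the measured compounds named here, no measured step isolates this change, so the evidence is indirect. The group on this nitrogen clearly matters in this assay, as shown by a 4.0-fold lower number from compound 1 to compound 2 (0.60 log units; beyond the scatter) and by the two steps to the 2-carboxyethyl group, a 6.3-fold higher number from compound 1 to compound 3 (0.80 log units; beyond the scatter) and a 25-fold higher number from compound 2 to compound 3 (1.40 log units; beyond the scatter). Like the groups of compound 1 and compound 2, 1-carboxyethyl is branched, but it keeps the carboxyl of compound 3. A partial recovery from the 5000 nM of compound 3 is therefore expected, smaller than the largest measured step and with wide uncertainty. The expected step is an 8.3-fold lower number from compound 3 to compound 4 (0.92 log units; beyond the scatter) and points to a lower number. Compound 4 is expected near 600 nM within a range from 80 nM to 4000 nM as estimated here.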

Compound 4, half-maximal inhibitory concentration: 15 nM
Beside the measured number, compound 4's estimate is 40-fold (1.60 log units) above it; the whole stated range lies above it.
By their numbers in this assay, from the lowest: compound 4; then compound 2; then compound 1; then compound 3.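

Moving the carboxyl within the chain on the nitrogen, with the same atoms joined differently, gives a 330-fold lower number from compound 3 to compound 4 (2.52 log units; beyond the scatter) in this assay, so a carboxyl at this position does not in itself go with a weak number, and how it is attached to the nitrogen matters greatly. The earlier compounds shown here could be read as favouring the methoxycarbonyl-bearing groups over a carboxyl, but 1-carboxyethyl goes past both of them, with a 13-fold lower number from compound 2 to compound 4 (1.12 log units; beyond the scatter) and with a 53-fold lower number from compound 1 to compound 4 (1.73 log units; beyond the scatter); neither a methoxycarbonyl nor a 4-chlorophenyl is therefore needed here for a low number. Nothing shown explains why so small a rearrangement produces so large a step.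

Compound 4 is the only compound shown with a defined stereocentre at this position, so what its opposite configuration at that carbon would give stays open, and so does the contribution of the stereocentre to the step. Also open, as far as these compounds go, are the methyl ester of 1-carboxyethyl, which would separate the acid from the ester on the same branched chain, and a longer chain such as 1-carboxypropyl.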